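Replacing Iodine with a Thiophene Ring on the Shared Core

The source may report more compounds than this note shows. Statements on the series, on what has been measured and on what is new or still open speak of the compounds shown alone.

Of the compounds shown here, three have been tested in a functional assay on HeLa S3 cells (Homo sapiens) for antiproliferative activity, read by XTT assay, with a stated time of 72 h; a higher number here means a weaker inhibitor, a lower number a stronger inhibitor. Compound 1 `Nc1nc(N)c2c(-c3ccsc3)cn([C@@H]3O[C@H](CO)[C@@H](O)[C@H]3O)c2n1` returns only a limit of the assay, > 20000 nM. Compound 2 `Cc1ncnc2c1c(-c1ccoc1)cn2[C@@H]1O[C@H](CO)[C@@H](O)[C@H]1O` likewise gives only a limit, > 20000 nM. Within the data shown here, compound 3 `Cc1nc(N)c2c(I)cn([C@@H]3O[C@H](CO)[C@@H](O)[C@H]3O)c2n1` is the one member with a measured number, 4180 nM in this assay, while the other two sit at the limit of > 20000 nM in this assay, at which 2 of the 3 values shown sit. Compound 4 `Cc1nc(N)c2c(-c3ccsc3)cn([C@@H]3O[C@H](CO)[C@@H](O)[C@H]3O)c2n1` has not yet been measured; it differs from compound 3 by thiophen-3-yl in place of iodo on an aromatic carbon. Among the measured compounds shown here, no step between two measured compounds is available to anchor this change. With compound 1 carrying the same thiophen-3-yl group and showing only a limit, a loss of potency is expected, and the step of a 2.2-fold higher number from compound 3 to compound 4 (0.33 log units; beyond the scatter) is estimated to lie beyond the usual scatter. For compound 4 an inhibitory concentration near 9000 nM is expected, between 2500 nM and 30000 nM.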

Compound 4, half-maximal inhibitory concentration: > 20000 nM
Compound 4: a limit, no number (the forecaster's own chance of this, stated with the estimate: 40%); at least 2.2-fold (0.34 log units) between middle value and limit.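

In this assay, among these compounds, thiophen-3-yl in place of iodo on an aromatic carbon of the shared core gives an at least 4.7-fold higher number from compound 3 to compound 4 (0.67 log units; beyond the scatter), the first measured step for this change. The step between compound 1 and compound 4 cannot be read, as both values are limits. Compound 3, with iodo, remains the only member with a measured number, and the rest of the series sits at one limit: the limit of > 20000 nM in this assay, at which 3 of the 4 values shown sit.

On these data alone, how far compound 4 lies past its limit stays open. As far as these compounds go, whether bromo, ethynyl or a phenyl ring on this carbon would give a measured number also stays open.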